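A few compounds are considered here, and "the series" means these few. Any claim that something is new, unique, unknown or untested is made for them only; others in the source may bear on it.

Compound 1, `CCc1ccc(NC(=O)Nc2cc(C)nc3ccccc23)cc1`, was tested in an ADME assay on HepG2 cells (Homo sapiens) for cytotoxicity, with a stated time of 72 h (on this read-out lower numbers stand for an effect already at smaller amounts and higher numbers for an effect only at larger amounts of compound), where compound 1 gives 17000 nM. Among the compounds with values here, compound 2, `Cc1cc(NC(=O)Nc2cccc(OC(F)(F)F)c2)c2ccccc2n1`, is the only other measured member of the series, and in this assay compound 2 gives 13000 nM. The two numbers lie within the scatter of each other, so no order between compound 1 and compound 2 can be read from them; compound 1 is simply one of two closely placed points.

Compound 3, `Cc1cc(NC(=O)Nc2ccc(Cl)cc2)c2ccccc2n1`, has not yet been measured. It differs from compound 1 in one place: chloro in place of ethyl on an aromatic carbon. Within the data shown here, no step between two measured compounds is known that would show what such a change does in this assay. With both measured numbers standing close together, a step from compound 1 to compound 3 of no more than the scatter, in either direction, is expected. The step of a 1.1-fold lower number from compound 1 to compound 3 (0.05 log units; within the scatter) that this estimate means is expected to stay within the scatter. Compound 3 is expected to give about 15000 nM, in a range from 7000 nM to 32000 nM.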

Compound 3, half-maximal effective concentration: > 25000 nM
Compound 3 gave a limit, no number; the forecaster's own chance of this, stated with the estimate: 15%; middle value at least 1.6-fold (0.22 log units) away from the limit.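

With chloro in place of ethyl on the aromatic carbon para to a large group, the series now has its first step at a single position, an at least 1.4-fold higher number from compound 1 to compound 3 (0.16 log units; that floor lies within the scatter) in this assay. That step has only a floor, so it does not separate compound 3 from compound 1, and its true size cannot be read. Compound 3 is the only compound shown that reaches a limit, which is not a number: the limit of > 25000 nM in this assay, at which 1 of the 3 values shown sits.

On these data alone, whether chloro at this position truly moves the value beyond the scatter therefore stays open. As far as these compounds go, what an amine or a carboxylic acid on the same aromatic carbon would give in this assay also stays open, as does whether a longer chain in place of ethyl would leave the value of compound 1 where it stands.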